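Replacing 3-(trifluoromethyl)phenyl with pyridin-3-yl

The source may hold more compounds than are shown below. What is called first, only, known or untested is meant among the compounds shown, and "the series" means these compounds.

In a functional assay on A-375 cells (Homo sapiens) for antiproliferative activity (on this read-out lower numbers stand for stronger inhibition and higher numbers for weaker inhibition), compound 1 `O=C(Nc1ccc(-c2cscn2)cc1)C1CCCN(Cc2ccc(F)c(F)c2)C1` gives 880 nM and compound 2 `O=C(Nc1ccc(-c2cscn2)cc1)C1CCCN(Cc2cc(F)cc(F)c2)C1` gives 1360 nM. Moving a fluorine on the ring barely registers, with a 1.5-fold higher number from compound 1 to compound 2 (0.19 log units; within the scatter).

Compound 3 `O=C(Nc1ccc(-c2cscn2)cc1)C1CCCN(Cc2cccc(C(F)(F)F)c2)C1` gives only a limit in this assay, > 20000 nM, and not a number. Its 3-(trifluoromethyl)phenyl group therefore marks a sharp break from the two difluorophenyl compounds, with an at least 22-fold higher number from compound 1 to compound 3 (1.35 log units; beyond the scatter) and an at least 14-fold higher number from compound 2 to compound 3 (1.16 log units; beyond the scatter).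

Compound 4 `O=C(Nc1ccc(-c2cscn2)cc1)C1CCCN(Cc2cccnc2)C1` changes that same group: pyridin-3-yl in place of 3-(trifluoromethyl)phenyl on a saturated chain carbon bound to an amine nitrogen in a ring. Pyridin-3-yl takes the place of 3-(trifluoromethyl)phenyl on a saturated chain carbon bound to an amine nitrogen in a ring, and the rest of the molecule stays the same.

The steps to compound 3 are the relevant evidence, since they are made at this same place. Compound 4 lacks the trifluoromethyl group, as do compound 1 at 880 nM and compound 2 at 1360 nM, so a return toward those values seems likely. For the measured compounds named here, no measured compound carries pyridin-3-yl, however, so only a partial return is expected.

The expected change is an at least 5.0-fold lower number from compound 3 to compound 4 (0.69 log units; beyond the scatter), toward stronger inhibition. The estimate for compound 4 is 4000 nM, with an expected range from 900 nM to 18000 nM.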

Compound 4, half-maximal inhibitory concentration: > 20000 nM
Compound 4: a limit, no number (the forecaster's own chance of this, stated with the estimate: 25%); at least 5.0-fold (0.69 log units) between middle value and limit.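

Taking away the trifluoromethyl group does not by itself restore activity at this place, on a saturated chain carbon bound to an amine nitrogen in a ring. Pyridin-3-yl also falls far short of the two difluorophenyl groups, with an at least 22-fold higher number from compound 1 to compound 4 (1.35 log units; beyond the scatter) and with an at least 14-fold higher number from compound 2 to compound 4 (1.16 log units; beyond the scatter). The step between compound 3 and compound 4 cannot be read, but two quite different rings, one carrying trifluoromethyl and one containing a nitrogen, now end at the same assay limit: the limit of > 20000 nM in this assay, at which 2 of the 4 values shown sit.

The compounds shown leave open whether the fluorines on the ring are what keeps compound 1 and compound 2 measurable, a question that an unsubstituted phenyl group or a pyridine ring carrying fluorine could address. As far as these compounds go, how much weaker compound 3 and compound 4 really are also stays open, and so does any order between them, since neither has a measured number.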